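From 4-methylbenzyl to benzyl: what to expect of compound 3

A few compounds are considered here, and "the series" means these few. Any claim that something is new, unique, unknown or untested is made for them only; others in the source may bear on it.

Compound 1 `O=C(CCC1C(=O)N(c2ccc(Cl)cc2)C(=O)N1Cc1ccc(Br)cc1)Nc1ccc(C(=O)NO)cc1`: 1250 nM
Compound 2 `Cc1ccc(CN2C(=O)N(c3ccc(Cl)cc3)C(=O)C2CCC(=O)Nc2ccc(C(=O)NO)cc2)cc1`: 830 nM

In a functional assay on HCT-116 cells (Homo sapiens) for antiproliferative activity, read by MTT assay, with a stated time of 48 h (a lower number here means a stronger inhibitor, a higher number a weaker inhibitor), compound 2 cannot be told apart from compound 1, as their values lie within the scatter of each other. Compound 3 `O=C(CCC1C(=O)N(c2ccc(Cl)cc2)C(=O)N1Cc1ccccc1)Nc1ccc(C(=O)NO)cc1`, not yet measured, differs from compound 2 in one place: hydrogen in place of methyl on an aromatic carbon. Among the compounds with values here, the one measured step that bears on this, a 1.5-fold lower number from compound 1 to compound 2 (0.18 log units; within the scatter), is methyl in place of bromo on an aromatic carbon. A change beyond the scatter is therefore not expected in this assay, and the expected step is a 1.2-fold higher number from compound 2 to compound 3 (0.08 log units; within the scatter). The estimate for compound 3 is 1000 nM, with an expected range from 450 nM to 2200 nM.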

Compound 3, half-maximal inhibitory concentration: 2250 nM
Beside the measured number, compound 3's estimate is 2.3-fold (0.35 log units) below it, outside the stated range (above it).
By their numbers in this assay, from the lowest: compounds 2, 1 and 3 (each within the scatter of the next, the first and the last beyond it).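

Within the data shown here, the change from 4-methylbenzyl to benzyl gives a 2.7-fold higher number from compound 2 to compound 3 (0.43 log units; beyond the scatter) in this assay and is the first step in this set to pass the scatter, so this position does respond to what sits on it. Hydrogen in place of bromo at the same position, with a 1.8-fold higher number from compound 1 to compound 3 (0.26 log units; within the scatter) here, stays within the scatter, so only the methyl and hydrogen compounds can be told apart. Nothing measured here explains this difference.

As far as these compounds go, whether a methoxy group, an amine or a carboxylic acid at this position would read like methyl or like hydrogen stays open.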